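Halogen pattern on the aryl ring of the oxime series

This account rests on a few compounds, and the source may have more. Where it says the series, first, only, none or still open, it means among the compounds named here.

Compound 1 `O/N=C(\CCN1CCN(c2ccccn2)CC1)c1ccccc1` gives 4.4 nM in a functional assay on HEK293 cells with D(4) dopamine receptor (Homo sapiens) as the target, read by FLIPR; on this read-out higher numbers stand for an effect only at larger amounts of compound and lower numbers for an effect already at smaller amounts. Compound 2 `Cc1ccccc1/C(CCN1CCN(c2ccccn2)CC1)=N\O` gives 20.3 nM in this assay, and compound 3 `O/N=C(\CCN1CCN(c2ccccn2)CC1)c1cccc(Cl)c1` gives 11.9 nM. Compound 3 thus stands second highest of the three numbers: its value and that of compound 2 lie within the scatter of each other, whereas the step of a 2.7-fold higher number from compound 1 to compound 3 (0.43 log units; beyond the scatter) lies beyond it.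

Compound 4 `O/N=C(\CCN1CCN(c2ccccn2)CC1)c1cc(F)cc(F)c1` differs from compound 3 by 3,5-difluorophenyl in place of 3-chlorophenyl on a carbon with a double bond to nitrogen. Going by the values given here, the only measured step that bears on this change is a 2.7-fold higher number from compound 1 to compound 3 (0.43 log units; beyond the scatter), a modest rise in the number when a halogen enters the aromatic ring. Among the compounds with values here, no measured pair compares one halogen with two, nor chlorine with fluorine, so the direction of a further halogen is not known from these data. For compound 4 the expected step is a 1.3-fold higher number from compound 3 to compound 4 (0.13 log units; within the scatter), a small rise or none beyond the scatter. The estimate for compound 4 in this assay is 16 nM, with a range from 7 nM to 40 nM.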

Compound 4, half-maximal effective concentration: 19.4 nM
The estimate for compound 4 lay 1.2-fold (0.08 log units) below the measured number; the measured number falls inside the stated range.
By their numbers in this assay, from the lowest: compound 1; then compounds 3, 4 and 2 (each within the scatter of the next).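

In this assay, 3,5-difluorophenyl in place of 3-chlorophenyl on a carbon with a double bond to nitrogen gives a 1.6-fold higher number from compound 3 to compound 4 (0.21 log units; within the scatter), so these two halogen patterns cannot be told apart at this position. Against the plain phenyl, the same ring gives a 4.4-fold higher number from compound 1 to compound 4 (0.64 log units; beyond the scatter), so a second halogenated ring now also separates from compound 1 by more than the scatter, and the earlier step to compound 3 is no longer a lone case. No measured information accounts for these numbers.

On these data alone, compounds 3 and 4 differ in both the kind and the number of halogens, so the contribution of each remains open. Also open, as far as these compounds go, is how a ring carrying a single fluorine, a methoxy group or a trifluoromethyl group would read in this assay.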